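Removal of the terminal sugar from compound 2

The source may hold more compounds than are shown below. What is called first, only, known or untested is meant among the compounds shown, and "the series" means these compounds.

Measured compounds in an assay for inhibition of glucose-6-phosphatase catalytic subunit 1 (Rattus norvegicus), tested at 100 uM; on this read-out lower numbers stand for less inhibition and higher numbers for more inhibition at the one concentration tested (going by the name of the read-out):
compound 1 `COc1ccc(/C=C/C(=O)C[C@@H]2OC[C@@H](O)[C@H](O)[C@H]2O)cc1OC`: -19.9%
compound 2 `O=C(/C=C/c1ccccc1)C[C@@H]1O[C@H](CO)[C@@H](O[C@@H]2O[C@H](CO)[C@@H](O)[C@H](O)[C@H]2O)[C@H](O)[C@H]1O`: -16.3%
compound 3 `O=C(/C=C/c1ccc2ccccc2c1)C[C@@H]1O[C@H](CO)[C@@H](O[C@@H]2O[C@H](CO)[C@@H](O)[C@H](O)[C@H]2O)[C@H](O)[C@H]1O`: -3.9%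

Compound 2 sits second highest of the three numbers in this assay. Compound 1 lies nearest, a number a few points lower and within the scatter, so the two cannot be ordered; compound 3 lies furthest, and the step of a number 12.4 percentage points higher from compound 2 to compound 3 (beyond the scatter) is the only one beyond the scatter in the set.

Compound 4 `O=C(/C=C/c1ccccc1)C[C@@H]1O[C@H](CO)[C@@H](O)[C@H](O)[C@H]1O` differs from compound 2 in one place: hydrogen in place of 3,4,5-trihydroxy-6-(hydroxymethyl)oxan-2-yl on an oxygen on a saturated carbon. Going by the values given here, no measured step touches this part of the molecule; the single step with a readable size, a number 12.4 percentage points higher from compound 2 to compound 3 (beyond the scatter), concerns the aryl group on the chain and says nothing about the outer sugar. Compound 1, which also lacks the second sugar, gives a value within the scatter of compound 2, but it differs in the aryl group as well, so that pair cannot be read as a step for the sugar alone.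

Among the compounds with values here, with no bearing step, the expectation for compound 4 is a number close to compound 2 and no step beyond the scatter, a number 1.3 percentage points higher from compound 2 to compound 4 (within the scatter). The estimated value for compound 4 in this assay is -15%, within -30% to 0%.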

Compound 4, a percentage reported as inhibition, at one concentration (the size of the read-out at that concentration, not a potency): -49.7%
The estimate for compound 4 lay 34.7 percentage points above the measured number, and the stated range ends above it.
By their numbers in this assay, from the lowest: compound 4; then compounds 1 and 2 (each within the scatter of the next); then compound 3.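

In this assay, the oxygen on a saturated carbon that carries the outer sugar is now shown to be a position where the read-out can move: with hydrogen in place of 3,4,5-trihydroxy-6-(hydroxymethyl)oxan-2-yl, the result is a number 33.4 percentage points lower from compound 2 to compound 4 (beyond the scatter). The only earlier step, a number 12.4 percentage points higher from compound 2 to compound 3 (beyond the scatter), concerned the aryl group on the chain and ran towards higher numbers, so the aryl group and this oxygen substituent are now both known to affect the number, in opposite directions for the changes shown. No measurement at hand accounts for the size or the direction of the new step.

It remains open whether the step carries over to the naphthalen-2-yl compound, since removal of the outer sugar is shown only with phenyl on the chain. Going by these compounds, it is also open whether the whole sugar is needed for the higher number or whether a smaller group on the same oxygen, such as a methyl ether or an acetyl ester, would give a number near that of compound 2 or near that of compound 4.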